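Mirror Image of Compound 3: Expected Agonist Potency

This account rests on a few compounds, and the source may have more. Where it says the series, first, only, none or still open, it means among the compounds named here.

Compound 1 `Clc1ccc(N2CC[C@H]3CN[C@H]3C2)cn1`: 29 nM
Compound 2 `Clc1ccc(N2CC[C@@H]3CN[C@@H]3C2)cn1`: 25 nM
Compound 3 `Clc1cc(N2CC[C@H]3CN[C@H]3C2)cnc1Cl`: 9.9 nM

All three were tested in a functional assay on HEK293 cells for agonist activity at Neuronal acetylcholine receptor; alpha3/beta4 (Homo sapiens), read by FLIPR; a higher number here means that more compound is needed for the effect, a lower number that less compound is needed. Compound 3 gives the lowest of the three numbers; the nearest is compound 2 and the furthest compound 1, and both of those gaps lie beyond the scatter. The step from compound 1 to compound 3 was a 2.9-fold lower number from compound 1 to compound 3 (0.47 log units; beyond the scatter), a chloro in place of hydrogen on an aromatic carbon.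

Compound 4 `Clc1cc(N2CC[C@@H]3CN[C@@H]3C2)cnc1Cl` differs from compound 3 as follows: the two compounds have the same atoms and bonds and differ only in configuration as drawn: 2 of 2 stereo elements differ (all stereocentres are inverted: mirror images); a stereocentre at a saturated ring carbon is drawn S in compound 3 and R in compound 4; a stereocentre at a saturated ring carbon is drawn R in compound 3 and S in compound 4. Among the compounds with values here, the one measured step that bears on this is a 1.2-fold lower number from compound 1 to compound 2 (0.06 log units; within the scatter), which is relevant due to the fact that compounds 1 and 2 differ only in the configuration as drawn. The expected step is therefore none beyond the scatter, a 1.0-fold higher number from compound 3 to compound 4 (0.00 log units; within the scatter). Compound 4 is estimated at 10 nM, with a range from 5 nM to 22 nM.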

Compound 4, half-maximal effective concentration: 110 nM
Compound 4: middle estimate off by 11-fold (1.04 log units), on the low side, outside the stated range (above it).
By their numbers in this assay, from the lowest: compound 3; then compounds 2 and 1 (each within the scatter of the next); then compound 4.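

Inverting both stereocentres made almost no difference without the added chloro, but with it the change matters: there is an 11-fold higher number from compound 3 to compound 4 (1.05 log units; beyond the scatter). The same chloro therefore acts in opposite directions on the two mirror-image cores, and on this second core there is a 4.4-fold higher number from compound 2 to compound 4 (0.64 log units; beyond the scatter). The effect of the chloro thus depends on the configuration of the core: the same change on two cores in this assay, a 2.9-fold lower number (0.47 log units; beyond the scatter) from compound 1 to compound 3 and a 4.4-fold higher number (0.64 log units; beyond the scatter) from compound 2 to compound 4, 13-fold (1.11 log units) apart, beyond the scatter of two such steps

The compounds shown leave open why the two mirror-image cores respond so differently to the chloro. They also leave open whether a bromo or a methyl group in place of that chloro would separate the mirror images as widely.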